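A few compounds are considered here, and "the series" means these few. Any claim that something is new, unique, unknown or untested is made for them only; others in the source may bear on it.

Measured compounds:
compound 1 `CCCCCCCCCCCCCCCCCCNC(=O)[C@@H](N)[C@@H](C)O`: 44500 nM
compound 2 `CCCCCCCCCCCCCCNC(=O)[C@@H](NC(=O)/C=C/c1ccccc1)[C@@H](C)O`: 150000 nM
compound 3 `CCCCCCCCCCCCCCNC(=O)[C@@H](NS(=O)(=O)c1ccc(C)cc1)[C@@H](C)O`: 10900 nM

In a functional assay on HepG2 cells (Homo sapiens) for cytotoxicity, read by MTT assay, with a stated time of 48 h (on this read-out lower numbers stand for stronger inhibition and higher numbers for weaker inhibition), compound 1 gives 44500 nM, the second highest of the three numbers; compound 2 gives a higher number and compound 3 a lower one. Compound 4 `C/C=C/C=C/C(=O)N[C@H](C(=O)NCCCCCCCCCCCCCCCCCC)[C@@H](C)O` differs from compound 1 by (penta-1,3-dien-1-yl)carbonyl in place of hydrogen on an amine nitrogen. Among the measured compounds shown here, no measured step covers exactly this change. Compound 2 and compound 3 both carry a group on the amine nitrogen, and a 14-fold lower number from compound 2 to compound 3 (1.14 log units; beyond the scatter) shows that the choice of that group carries a large step. Compound 2, with (2-phenylethenyl)carbonyl there, sits at the highest number of the set, and compound 4 with (penta-1,3-dien-1-yl)carbonyl resembles it more than compound 3. A step to a higher number is therefore expected, a 2.2-fold higher number from compound 1 to compound 4 (0.35 log units; beyond the scatter). Compound 4 is estimated at 100000 nM, within 30000 nM to 300000 nM.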

Compound 4, half-maximal inhibitory concentration: 284000 nM
For compound 4 the middle estimate is 2.8-fold (0.45 log units) below the measured one, within the range that was stated.
By their numbers in this assay, from the lowest: compound 3; then compound 1; then compounds 2 and 4 (each within the scatter of the next).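

In this assay, among the compounds shown here, (penta-1,3-dien-1-yl)carbonyl in place of hydrogen on the amine nitrogen gives a 6.4-fold higher number from compound 1 to compound 4 (0.80 log units; beyond the scatter), the only step here measured against the free amino group. For this one pair, acylation of that nitrogen weakens inhibition, whereas the earlier step compared only two substituted nitrogens. No measurement at hand explains this step.

Open, as far as these compounds go, is whether a small acetyl group on that nitrogen moves the number the same way as (penta-1,3-dien-1-yl)carbonyl. Also open, from the compounds shown here alone, is how (4-methylphenyl)sulfonyl there behaves with the chain of compound 1.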